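Ester series: sulfamoyl for carbamoyl on the aryl ring

The source may report more compounds than this note shows. Statements on the series, on what has been measured and on what is new or still open speak of the compounds shown alone.

Measured so far:
compound 1 `CC(C)c1noc(N2CCN(C(=O)[C@@H]3CCCN(S(=O)(=O)c4ccc(S(=O)(=O)C(C)C)cc4)C3)CC2)n1` — 70 nM
compound 2 `CCOC(=O)[C@@H]1CCCN(S(=O)(=O)c2ccc(C(=O)N(CC)CC)cc2)C1` — 800 nM
compound 3 `CCOC(=O)[C@@H]1CCC[C@@H](S(=O)(=O)c2ccc(S(=O)(=O)N(CC)CC)cc2)C1` — 16400 nM

In a functional assay on MIA PaCa-2 cells (Homo sapiens) for inhibition, read by MTT assay, with a stated time of 7 days (on this read-out higher numbers stand for weaker inhibition and lower numbers for stronger inhibition), compound 2 gives 800 nM, the second highest of the three numbers: it sits beyond the scatter below compound 1 and beyond the scatter above compound 3. Compound 4 `CCCN(CC)S(=O)(=O)c1ccc(S(=O)(=O)N2CCC[C@@H](C(=O)OCC)C2)cc1` is the next analogue of compound 2; the change is ethyl(propyl)sulfamoyl in place of diethylcarbamoyl on an aromatic carbon. Among the measured compounds shown here, no measured pair shows this exact change, and compound 3 carries its sulfamoyl on a differently built core, so it gives no direct guide. A modest step toward a higher number is expected, possibly within the scatter, a 1.5-fold higher number from compound 2 to compound 4 (0.18 log units; within the scatter). Compound 4 is estimated at 1200 nM in this assay, in the range 400 nM to 4000 nM.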

Compound 4, half-maximal inhibitory concentration: 300 nM
For compound 4 the middle estimate is 4.0-fold (0.60 log units) above the measured one; measured number outside the range, below it.
By their numbers in this assay, from the lowest: compound 1; then compound 4; then compound 2; then compound 3.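

In this assay, ethyl(propyl)sulfamoyl in place of diethylcarbamoyl on an aromatic carbon, para to a large group, gives a 2.7-fold lower number from compound 2 to compound 4 (0.43 log units; beyond the scatter) and thus a modest gain at this position. Among the compounds shown here, this is the first one-place comparison, and it shows that the position tolerates the larger sulfur-bearing group. No measured evidence accounts for the step.

Still open, going by these compounds, is whether diethylsulfamoyl on the shared core would match compound 4, separating the effect of the sulfamoyl link from that of the propyl chain. A morpholine sulfonyl group or a longer butyl chain at this position would test how far the gain extends.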